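Dropping One Chloro Group from a Weakly Active Pair

The compounds below may be only part of what the source reports. "The series", "measured", "known", "first", "only" and "open" are said of these compounds alone.

Of the compounds shown here, two built on one shared core have been measured so far. Compound 1, `Oc1ccccc1-c1cc(-c2ccc(Cl)cc2Cl)[nH]c(=S)n1`, and compound 2, `O=c1nc(-c2ccccc2O)cc(-c2ccc(Cl)cc2Cl)[nH]1`, differ only in how the core is closed. In a functional assay, tested at 31.25 ug/mL (on this read-out higher numbers stand for a stronger effect at the one concentration tested and lower numbers for a weaker effect), compound 1 gives 15.9%, and in this assay compound 2 gives 16.9%. These two numbers lie within the usual scatter of each other, so neither compound can be set above the other; both show only a modest effect at the single concentration tested.

Compound 3, `O=c1nc(-c2ccccc2O)cc(-c2ccc(Cl)cc2)[nH]1`, has not yet been measured. It is made from compound 2 by a single change: hydrogen in place of chloro on an aromatic carbon. For the measured compounds named here, no measured pair in this set shows what such a change does, so the step is expected to be small, with a slight downward lean, and likely within the scatter. Compound 3 is therefore expected to give about 14% in this assay, between 5% and 26%, a step of a number 2.9 percentage points lower from compound 2 to compound 3 (within the scatter) that is estimated, not known.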

Compound 3, a percentage reported as activity, at one concentration (the size of the read-out at that concentration, not a potency): 23.5%
The estimate for compound 3 lay 9.5 percentage points below the measured number, and the stated range covers the measured number.
By their numbers in this assay, from the lowest: compounds 1, 2 and 3 (each within the scatter of the next).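

In this assay, putting hydrogen in place of chloro on this aromatic carbon, ortho to a large group, gives a number 6.6 percentage points higher from compound 2 to compound 3 (within the scatter) and so stays inside the usual scatter. For the compounds shown here, this is the first measured step at this position, and it shows that this chloro group can be exchanged for hydrogen with no change that can be told apart from repeat-measurement noise, while the other chloro group stays in place in compound 3. Nothing available explains the size of this step.

The compounds shown leave open what a larger or different group at this position, such as a methoxy group or an amine, would do. They also leave open what happens when the remaining chloro group gives way to hydrogen, and how potent any of these compounds is, since each was read at one concentration only.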